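Inversion of configuration in the fluoromethylethyl carbamate

The source may report more compounds than this note shows. Statements on the series, on what has been measured and on what is new or still open speak of the compounds shown alone.

Among the compounds with values here, compound 3 `C[C@H](CF)OC(=O)N1CCC(O[C@H]2CC[C@H](Oc3cnc(S(C)(=O)=O)cn3)CC2)CC1` gives 317 nM in a functional assay on isolated protein for agonist activity at Glucose-dependent insulinotropic receptor (Rattus norvegicus), read by HTRF and cAMP accumulation (on this read-out lower numbers stand for an effect already at smaller amounts and higher numbers for an effect only at larger amounts of compound), the highest of the three numbers measured so far. Compound 1 `CC(C)(C)OC(=O)N1CCC(O[C@H]2CC[C@H](Oc3cnc(S(C)(=O)=O)cn3)CC2)CC1` gives 64 nM and compound 2 `CC1(OC(=O)N2CCC(O[C@H]3CC[C@H](Oc4cnc(S(C)(=O)=O)cn4)CC3)CC2)CC1` gives 138 nM. The measured steps all concern exchange of the group on the oxygen next to the carbonyl: a 2.2-fold higher number from compound 1 to compound 2 (0.33 log units; beyond the scatter), a 5.0-fold higher number from compound 1 to compound 3 (0.69 log units; beyond the scatter) and a 2.3-fold higher number from compound 2 to compound 3 (0.36 log units; beyond the scatter).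

Compound 4 `C[C@@H](CF)OC(=O)N1CCC(O[C@H]2CC[C@H](Oc3cnc(S(C)(=O)=O)cn3)CC2)CC1` differs from compound 3 only in configuration: the two compounds have the same atoms and bonds and differ only in configuration as drawn: 2 of 3 stereo elements differ; a stereocentre at a saturated chain carbon is drawn R in compound 3 and S in compound 4; a stereocentre at a saturated ring carbon is drawn R in compound 3 and S in compound 4. Within the data shown here, none of the measured steps is a change of configuration, so no step bears directly on this one; the three steps only show that changes at this position have moved the number by modest amounts. Among the measured compounds shown here, with no measured precedent for an inversion, the expectation is neutral, and a step no larger than the scatter is expected, with a wide range to allow for either direction: a 1.1-fold lower number from compound 3 to compound 4 (0.02 log units; within the scatter).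

Compound 4 is therefore estimated to give 300 nM in this assay, within a range from 100 nM to 900 nM.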

Compound 4, half-maximal effective concentration: 356 nM
Compound 4: the middle estimate sits 1.2-fold (0.07 log units) below what was measured; the measured number falls inside the stated range.
By their numbers in this assay, from the lowest: compound 1; then compound 2; then compounds 3 and 4 (each within the scatter of the next).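

In this assay the change of configuration gives a 1.1-fold higher number from compound 3 to compound 4 (0.05 log units; within the scatter), so at this position the two drawn forms of the 1-(fluoromethyl)ethyl carbamate are not separated, a point the earlier exchanges of group could not show. The identity of the group on the oxygen next to the carbonyl remains what sets the steps seen so far: 1-(fluoromethyl)ethyl in place of 1-methylcyclopropyl gives a 2.6-fold higher number from compound 2 to compound 4 (0.41 log units; beyond the scatter), and 1-(fluoromethyl)ethyl in place of tert-butyl gives a 5.6-fold higher number from compound 1 to compound 4 (0.75 log units; beyond the scatter), so compound 3 and compound 4 both carry higher numbers than compound 1 and compound 2, with neither compound going against this. The comparison isolates stereochemistry alone, with no exchange of group involved: the fact that compounds 3 and 4 differ only in the configuration as drawn.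

The compounds shown do not separate the contribution of the saturated chain carbon from that of the saturated ring carbon, as both differ together in this one pair. Also open, as far as these compounds go, is how the number responds to a longer chain or a trifluoroethyl group on the oxygen next to the carbonyl.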